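This account rests on a few compounds, and the source may have more. Where it says the series, first, only, none or still open, it means among the compounds named here.

Compound 1 `C=C1CC[C@H]2C(C)(C)CCC[C@]2(C)[C@H]1CC/C(C)=C/Cc1c(O)cc(O)c2c(=O)c(O)c(-c3ccc(O)cc3)oc12` and compound 2 `C=C1CC[C@H]2C(C)(C)CCC[C@]2(C)[C@H]1CC/C(C)=C/COc1c(-c2ccc(O)cc2)oc2cc(O)cc(O)c2c1=O` are built from the same atoms joined differently; the difference between the two cores is not broken down here. In a functional assay on HT-29 cells (Homo sapiens) for cytotoxicity, read by XTT assay, with a stated time of 72 h (on this read-out higher numbers stand for weaker inhibition and lower numbers for stronger inhibition), compound 1 gives 29000 nM. In this assay, within the data shown here, compound 2 gives 30000 nM, a number that lies within the scatter of the one for compound 1, so no order between the two can be read from it. Compound 3 `C=C1CC[C@H]2C(C)(C)CCC[C@]2(C)[C@H]1CC/C(C)=C/Cc1c(O)cc(O)c2c(=O)c(O)c(-c3ccc(OC)cc3)oc12` is obtained from compound 1 by the change (methyl in place of hydrogen on an oxygen on an aromatic ring). In this assay compound 3 reaches > 100000 nM, which is a limit of the assay and not a number. The step of an at least 3.4-fold higher number from compound 1 to compound 3 (0.53 log units; beyond the scatter) is therefore known only as a lower bound, and its size rests on (the limit of > 100000 nM in this assay, at which 1 of the 3 values shown sits).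

Compound 4 `C=C1CC[C@H]2C(C)(C)CCC[C@]2(C)[C@H]1CC/C(C)=C/COc1c(-c2ccc(OC)cc2)oc2cc(O)cc(O)c2c1=O` stands to compound 2 as compound 3 stands to compound 1: it differs by methyl in place of hydrogen on an oxygen on an aromatic ring, the same change at the same place. Since compound 2 sits within the scatter of compound 1 in this assay, and the change weakened compound 1 by an at least 3.4-fold higher number from compound 1 to compound 3 (0.53 log units; beyond the scatter), compound 4 is expected to lose in the same direction by about a 3.7-fold higher number from compound 2 to compound 4 (0.56 log units; beyond the scatter). On this basis compound 4 is estimated to come out near 110000 nM in this assay, with a plausible span from 50000 nM to 300000 nM, and it is quite possible that the assay will again report only a limit for compound 4.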

Compound 4, half-maximal inhibitory concentration: 32000 nM
Compound 4: the middle estimate sits 3.4-fold (0.54 log units) above what was measured; measured number outside the range, below it.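

On the second core, the change from hydroxy to methoxy gives a 1.1-fold higher number from compound 2 to compound 4 (0.03 log units; within the scatter), so in this assay it does not carry over as a fixed step from the core of compound 1: the same change on two cores in this assay, an at least 3.4-fold higher number (0.53 log units; beyond the scatter) from compound 1 to compound 3 and a 1.1-fold higher number (0.03 log units; within the scatter) from compound 2 to compound 4, at least 3.2-fold (0.50 log units) apart, beyond the scatter of two such steps

Compound 3 gives > 100000 nM, which is a limit of the assay and not a number, so the full size of the earlier step stays unknown: the limit of > 100000 nM in this assay, at which 1 of the 4 values shown sits.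

The two steps show that, in these two pairs of compounds, the outcome of replacing 4-hydroxyphenyl with 4-methoxyphenyl depends on the core it is placed on, but they do not show why the cores differ, and two pairs cannot tell how the change would behave on any further core.

The compounds shown leave open what other groups would do at that oxygen, such as an ethyl group or a longer chain in place of the methyl, and what an amine or a carboxylic acid would do in place of the hydroxy group on that ring. They also leave open whether the same change, made at the other hydroxy groups of these molecules, would depend on the core in the same way.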